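A few compounds are considered here, and "the series" means these few. Any claim that something is new, unique, unknown or untested is made for them only; others in the source may bear on it.

Three related molecules have numbers in a functional assay on A549 cells (Homo sapiens) for cytotoxicity, read by MTT assay, with a stated time of 72 h; on this read-out higher numbers stand for weaker inhibition and lower numbers for stronger inhibition. Compound 3 `CCN(CC)Cc1ccc2nc(NC(=O)N/N=C/c3c[nH]c4ccccc34)sc2c1`, which carries a hydrogen on its aromatic nitrogen, gives 3300 nM. Compound 2 `CCN(CC)Cc1ccc2nc(NC(=O)N/N=C/c3cn(Cc4ccc(Cl)cc4)c4ccccc34)sc2c1` gives 2940 nM, level with compound 3 within the scatter. Compound 1 `CN(C)Cc1ccc2nc(NC(=O)N/N=C/c3cn(Cc4ccccc4Cl)c4ccccc34)sc2c1` gives 1080 nM, which is clearly lower than the number for compound 3. Compound 3 therefore belongs to the upper pair of this small set.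

Compound 4 `CCN(CC)Cc1ccc2nc(NC(=O)N/N=C/c3cn(Cc4ccccc4Cl)c4ccccc34)sc2c1` differs from compound 3 in one place: 2-chlorobenzyl in place of hydrogen on an aromatic nitrogen. Two observations bear on this change. The closest measured step, a 1.1-fold higher number from compound 2 to compound 3 (0.05 log units; within the scatter), exchanges a 4-chlorobenzyl for hydrogen on the same nitrogen and stays within the scatter. This suggests that adding a chlorobenzyl group need not shift the number much. The 2-chlorobenzyl group itself appears in a molecule with a different amine group, and compound 1 at 1080 nM hints at a somewhat lower number. Taken together, these point to a modest drop at most, toward stronger inhibition. The estimated change is a 1.7-fold lower number from compound 3 to compound 4 (0.22 log units; within the scatter), a small step that is not expected to clearly exceed the scatter. Compound 4 is expected to give about 2000 nM, with an estimated range of 950 nM to 4000 nM.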

Compound 4, half-maximal inhibitory concentration: 1390 nM
The estimate for compound 4 lay 1.4-fold (0.16 log units) above the measured number, within the range that was stated.
By their numbers in this assay, from the lowest: compounds 1 and 4 (each within the scatter of the next); then compounds 2 and 3 (each within the scatter of the next).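

The aromatic nitrogen does respond to a chlorobenzyl group, but only in one of the two forms seen here: the 4-chlorobenzyl group stayed level with hydrogen, with a 1.1-fold higher number from compound 2 to compound 3 (0.05 log units; within the scatter), whereas the 2-chlorobenzyl group gives a 2.4-fold lower number from compound 3 to compound 4 (0.38 log units; beyond the scatter). The direct comparison of the two chlorobenzyl groups, a 2.1-fold lower number from compound 2 to compound 4 (0.33 log units; beyond the scatter), confirms that the place of the chlorine on the benzyl ring changes the number in this pair, so adding the benzyl ring alone does not account for the shift. The amine matters much less in this comparison: a 1.3-fold higher number from compound 1 to compound 4 (0.11 log units; within the scatter) stays within the scatter, so diethylamino and dimethylamino are level when the 2-chlorobenzyl group is present.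

The compounds shown leave open how a plain benzyl group, a 3-chlorobenzyl group or a 2-methylbenzyl group would compare on the same nitrogen, so it remains unclear whether chlorine itself is needed for the shift. No measurement is available here that explains the difference between the 2-chlorobenzyl and 4-chlorobenzyl groups.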